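Dopamine transporter binding: fluorine on the benzoyl ring

This account rests on a few compounds, and the source may have more. Where it says the series, first, only, none or still open, it means among the compounds named here.

Two members of the series have been measured. Compound 1 `Fc1ccc(C(SCCNC2CCN(Cc3ccccc3)CC2)c2ccc(F)cc2)cc1` carries a benzyl group on the ring nitrogen; in an assay on membranes from striatum (strain Sprague-Dawley) for displacement of a labelled ligand from sodium-dependent dopamine transporter (Rattus norvegicus), read by scintillation counting, with a stated time of 120 min (on this read-out lower numbers stand for stronger inhibition and higher numbers for weaker inhibition), compound 1 gives 32.9 nM. Compound 2 `O=C(c1ccccc1)N1CCC(NCCSC(c2ccc(F)cc2)c2ccc(F)cc2)CC1` carries a benzoyl group in that place, and in this assay compound 2 gives 4.51 nM. For the measured compounds named here, the single measured step, a 7.3-fold lower number from compound 1 to compound 2 (0.86 log units; beyond the scatter), is the only comparison in hand. Going by the values given here, on the numbers so far compound 2 holds the lowest value of the two, with compound 1 the nearest neighbour at the higher value.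

Compound 3 `O=C(c1ccc(F)cc1)N1CCC(NCCSC(c2ccc(F)cc2)c2ccc(F)cc2)CC1` differs from compound 2 by fluoro in place of hydrogen on an aromatic carbon. Among the compounds with values here, no measured step touches this change: the one step available swaps benzyl for benzoyl and says nothing about a substituent on the benzoyl ring. With nothing to build on beyond the anchor value of compound 2, no shift beyond the scatter is expected in this assay. The expected step is a 1.0-fold lower number from compound 2 to compound 3 (0.00 log units; within the scatter). For compound 3 in this assay the estimate is 4.5 nM, within 1.5 nM to 13 nM.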

Compound 3, inhibition constant: 7.04 nM
Estimate against measurement, compound 3: 1.6-fold (0.19 log units) below; low and high end bracket the measured number.
By their numbers in this assay, from the lowest: compounds 2 and 3 (each within the scatter of the next); then compound 1.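

In this assay the carbon para to a large group on the benzoyl ring takes a fluoro group without a step beyond the scatter, reading a 1.6-fold higher number from compound 2 to compound 3 (0.19 log units; within the scatter), so this single atom change leaves the number where compound 2 had it. The lower number that came with the benzoyl group in place of the benzyl group also holds with the 4-fluorophenyl carbonyl group, reading a 4.7-fold lower number from compound 1 to compound 3 (0.67 log units; beyond the scatter), so that step is now seen on two acyl members of the series, not one. Nothing at hand gives a reason for either reading.

Going by these compounds, one small substituent at one ring carbon is too little to show how wide the allowance at this position is: whether a methoxy group, a nitrile, a trifluoromethyl group or an amine on the same carbon would also stay within the scatter of compound 2 remains open. Also open, on these data alone, is whether fluoro on another carbon of this ring, or a longer chain between the carbonyl and the phenyl ring, would keep the number in this range.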